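The source may hold more compounds than are shown below. What is called first, only, known or untested is meant among the compounds shown, and "the series" means these compounds.

Compound 1 `COc1cc(/C=C/c2nccc(NC(C)C)n2)cc(OC)c1OC` and compound 2 `COc1cc(/C=C/c2nc(Cl)cc(NC(C)C)n2)cc(OC)c1OC` share one core. In a functional assay on L02 cells (Homo sapiens) for inhibition, read by Griess assay, with stated times of 1 h and 24 h (on this read-out higher numbers stand for weaker inhibition and lower numbers for stronger inhibition), compound 1 gives only a limit, < 40000 nM. In this assay compound 2 likewise gives only a limit, < 40000 nM. The change chloro in place of hydrogen on an aromatic carbon thus makes a step that the two limits leave unreadable from compound 1 to compound 2 because both values rest on (the limit of < 40000 nM in this assay, at which 2 of the 3 values shown sit). Compound 3 `C(=C/c1ccco1)\c1nc(NCc2ccccc2)c2sccc2n1` is built on another core; the difference between the two cores is not broken down here. In this assay compound 3 gives only a limit, > 1000000 nM. Compound 4 `Clc1ccc(CNc2nc(/C=C/c3ccco3)nc3ccsc23)cc1` carries the change (chloro in place of hydrogen on an aromatic carbon), the same kind of change as in the earlier pair, though here it sits on a six-membered aromatic ring of carbon only, para to a large group, rather than on a ring with 2 nitrogen, next to the ring nitrogen and meta to an isopropylamino group. Since the earlier step stays unreadable and compound 3 sits at the limit of > 1000000 nM in this assay, at which 1 of the 3 values shown sits, the expected step is a step that the limit leaves unreadable from compound 3 to compound 4, a small one. Compound 4 is estimated at 1500000 nM, likely falling from 300000 nM to 10000000 nM, and most probably reported only as a limit again.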

Compound 4, half-maximal inhibitory concentration: > 1000000 nM
Compound 4 gave a limit, no number (the forecaster's own chance of this, stated with the estimate: 80%); the middle value lies beyond the limit too.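

Within the data shown here, compound 3 and compound 4 both rest on a limit and not on a number, so no step from the one to the other can be read: the limit of > 1000000 nM in this assay, at which 2 of the 4 values shown sit. The compounds shown leave open whether chloro in place of hydrogen changes inhibition in this assay at all, on either core, and what the true value of each compound is.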